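Methoxy for nitro on the benzyl ether ring

This account rests on a few compounds, and the source may have more. Where it says the series, first, only, none or still open, it means among the compounds named here.

The series shares one core, seen in compound 1 `COc1cccc(OC)c1OCCNCCOc1ccccc1OCc1ccccc1`, which in a functional assay on thoracic aorta for antagonist activity at Alpha-1D adrenergic receptor (Rattus norvegicus) (on this read-out lower numbers stand for lower potency and higher numbers for higher potency (the scale is a negative logarithm)), gives 9.37. Compound 2 `COc1cccc(OC)c1OCCNCCOc1ccccc1OCc1cccc([N+](=O)[O-])c1` gives 9.28 in this assay, and compound 3 `COc1cccc(OC)c1OCCNCCOc1ccccc1OCc1ccc([N+](=O)[O-])cc1` gives 9.41. Compound 3 carries the highest of the three numbers, yet the step of a number 0.04 log units higher from compound 1 to compound 3 (within the scatter) and the step of a number 0.13 log units higher from compound 2 to compound 3 (within the scatter) both stay within the scatter, so no order among the three compounds can be read from these numbers.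

Compound 4 `COc1ccc(COc2ccccc2OCCNCCOc2c(OC)cccc2OC)cc1` differs from compound 3 by methoxy in place of nitro on an aromatic carbon, a methoxy in place of the nitro on an aromatic carbon, para to a large group. The measured steps that bear on this change are a number 0.09 log units lower from compound 1 to compound 2 (within the scatter) and the nitro-for-hydrogen step already named, both within the scatter; nothing in the set has moved this assay beyond the scatter. Expected for the change is a step of a number 0.06 log units lower from compound 3 to compound 4 (within the scatter), none beyond the scatter. Compound 4 is estimated at 9.35, with a range from 8.9 to 9.8.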

Compound 4, negative logarithm of the antagonist equilibrium constant: 9.21
Estimate against measurement, compound 4: 0.14 log units above; measured number inside the range.
By their numbers in this assay, from the lowest: compounds 4, 2, 1 and 3 (each within the scatter of the next).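

Methoxy in place of nitro, para to a large group, gives a number 0.20 log units lower from compound 3 to compound 4 (within the scatter), so in this assay the 4-methoxybenzyl group cannot be told apart from the 4-nitrobenzyl group. The other two new comparisons read the same way, with a number 0.16 log units lower from compound 1 to compound 4 (within the scatter) for methoxy in place of hydrogen and a number 0.07 log units lower from compound 2 to compound 4 (within the scatter) for 4-methoxyphenyl in place of 3-nitrophenyl, so hydrogen, nitro and methoxy at this position have now produced no step beyond the scatter. No measurement at hand accounts for this insensitivity.

It remains open whether any group on this ring can move the number beyond the scatter, since an amine, a carboxylic acid and a longer alkoxy chain are not among the compounds shown. Methoxy on the ring carbon that carries nitro in compound 2 also remains open.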